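Extending the methyl on the aromatic nitrogen to 4-chlorobenzyl

A few compounds are considered here, and "the series" means these few. Any claim that something is new, unique, unknown or untested is made for them only; others in the source may bear on it.

Compound 2 `Cn1cc(-c2coc(-c3ccc(Cl)cc3)n2)c2ccccc21` gives 637000 nM in a functional assay on MCF7 cells (Homo sapiens) for cytotoxicity, read by MTT assay, with a stated time of 48 h; on this read-out lower numbers stand for stronger inhibition and higher numbers for weaker inhibition; the only other point, compound 1 `Clc1ccc(-c2nc(-c3c[nH]c4ccccc34)co2)cc1`, gives 410000 nM, and the step of a 1.6-fold higher number from compound 1 to compound 2 (0.19 log units; within the scatter) lies within the scatter. Compound 3 `Clc1ccc(Cn2cc(-c3coc(-c4ccc(Cl)cc4)n3)c3ccccc32)cc1` carries 4-chlorophenyl in place of hydrogen on a saturated chain carbon bound to an aromatic nitrogen; cut one bond further out, this reads methyl to 4-chlorobenzyl. Among the compounds with values here, the one measured step at this position, a 1.6-fold higher number from compound 1 to compound 2 (0.19 log units; within the scatter), was small, and no measured step adds a ring of this kind, so for compound 3 the expected change is a 1.3-fold lower number from compound 2 to compound 3 (0.11 log units; within the scatter), with no clear direction. Compound 3 is estimated at 500000 nM, within 150000 nM to 1500000 nM.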

Compound 3, half-maximal inhibitory concentration: 14100 nM
Compound 3: the middle estimate sits 35-fold (1.55 log units) above what was measured; the measured number lies below the stated range.
By their numbers in this assay, from the lowest: compound 3; then compounds 1 and 2 (each within the scatter of the next).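

In this assay, the aromatic nitrogen of the shared core turns out to be a responsive position: methyl to 4-chlorobenzyl gives a 45-fold lower number from compound 2 to compound 3 (1.65 log units; beyond the scatter), and 4-chlorobenzyl in place of the hydrogen on that nitrogen gives a 29-fold lower number from compound 1 to compound 3 (1.46 log units; beyond the scatter). Methyl alone had stayed within the scatter, so among these compounds a large step appears only with the 4-chlorophenyl on the saturated chain carbon. Nothing at hand gives a reason for this step.

The compounds shown leave open whether the chlorine, the ring or the chain length carries the step. Unsubstituted benzyl, a longer chain ending in 4-chlorophenyl, or a chain ending in an amine would separate these.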